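The source may report more compounds than this note shows. Statements on the series, on what has been measured and on what is new or still open speak of the compounds shown alone.

In a functional assay on T98G cells (Homo sapiens) for cytotoxicity, read by MTT assay (on this read-out lower numbers stand for stronger inhibition and higher numbers for weaker inhibition), compound 2 (`Oc1ccc(CN(Cc2cccc(C(F)(F)F)c2)Cc2ccc(O)c3ncccc23)c2cccnc12`) gives 57 nM and compound 3 (`Oc1ccc(CN(Cc2cc(C(F)(F)F)cc(C(F)(F)F)c2)Cc2ccc(O)c3ncccc23)c2cccnc12`) gives 72 nM; the two stand level, with a 1.3-fold higher number from compound 2 to compound 3 (0.10 log units; within the scatter) for adding a trifluoromethyl. Compound 1 (`Oc1ccc(CN(Cc2ccccc2C(F)(F)F)Cc2ccc(O)c3ncccc23)c2cccnc12`) gives a clearly higher 210 nM, and 3-(trifluoromethyl)phenyl in place of 2-(trifluoromethyl)phenyl brings a 3.7-fold lower number from compound 1 to compound 2 (0.57 log units; beyond the scatter) as a modest step. Compound 4 (`Oc1ccc(CN(Cc2cccs2)Cc2ccc(O)c3ncccc23)c2cccnc12`) has thiophen-2-yl in place of 3-(trifluoromethyl)phenyl on a saturated chain carbon bound to an amine nitrogen. Among the compounds with values here, no measured step exchanges the whole ring, so these two steps offer only indirect guidance. A modest rise is expected, estimated as a 2.6-fold higher number from compound 2 to compound 4 (0.42 log units; beyond the scatter) in this read-out. For compound 4 the estimated value is 150 nM, with an expected range of 50 nM to 450 nM.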

Compound 4, half-maximal inhibitory concentration: 88 nM
Estimate against measurement, compound 4: 1.7-fold (0.23 log units) above, and the stated range covers the measured number.
By their numbers in this assay, from the lowest: compounds 2, 3 and 4 (each within the scatter of the next); then compound 1.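

In this assay, thiophen-2-yl, a five-membered aromatic ring without trifluoromethyl, stands level with 3-(trifluoromethyl)phenyl, with a 1.5-fold higher number from compound 2 to compound 4 (0.19 log units; within the scatter). This place therefore tolerates exchange of the whole ring, and trifluoromethyl is not required for a number in this range. The same group also gives a 2.4-fold lower number from compound 1 to compound 4 (0.38 log units; beyond the scatter), so the higher number of compound 1 does not extend to this ring. Nothing available explains these results. On these data alone, whether a saturated ring such as cyclohexyl, or a pyridine ring, would also hold this level remains open.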